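Adding a methoxy group to a trimethoxyphenyl-pyrazole chalcone

This account rests on a few compounds, and the source may have more. Where it says the series, first, only, none or still open, it means among the compounds named here.

Three related chalcone-type compounds have been tested in a functional assay on HT-29 cells (Homo sapiens) for inhibition, read by sulforhodamine B assay, with a stated time of 48 h; a lower number here means that less compound is tolerated, a higher number that more compound is tolerated. Compound 1 `COc1ccc(-c2cc(/C=C/C(=O)c3ccc(N)cc3)[nH]n2)cc1` gives 74100 nM. Compound 3 `COc1ccc(-c2cc(/C=C/C(=O)c3ccc(N)cc3)[nH]n2)cc1OC`, which carries a methoxy in place of hydrogen on an aromatic carbon, gives 58900 nM; the step of a 1.3-fold lower number from compound 1 to compound 3 (0.10 log units; within the scatter) is small. Compound 2 `COc1ccc(C(=O)/C=C/c2cc(-c3cc(OC)c(OC)c(OC)c3)n[nH]2)cc1OC` gives 5750 nM, the lowest of the three numbers, set apart from compound 3 and compound 1 by steps that lie beyond the scatter. The difference between the core of compound 2 and that of compound 1 is not broken down here.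

Compound 4 `COc1cc(C(=O)/C=C/c2cc(-c3cc(OC)c(OC)c(OC)c3)n[nH]2)cc(OC)c1OC` has not yet been measured. It differs from compound 2 by a methoxy in place of hydrogen on an aromatic carbon. Going by the values given here, this is the same kind of change as the one from compound 1 to compound 3, though the surroundings differ: in compound 4 the new methoxy is also meta to a methoxy group, whereas in compound 3 it is only ortho to a methoxy group and meta to a large group.

Because the earlier step of a 1.3-fold lower number from compound 1 to compound 3 (0.10 log units; within the scatter) stayed within the scatter, a step of similar size is expected, and the step from compound 2 to compound 4 is estimated at a 1.2-fold lower number from compound 2 to compound 4 (0.06 log units; within the scatter). On that basis compound 4 is expected to give about 5000 nM in this assay, most likely between 2500 nM and 12000 nM.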

Compound 4, concentration lethal to 50% of the cells: 6360 nM
The estimate for compound 4 lay 1.3-fold (0.10 log units) below the measured number, within the range that was stated.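

Compound 4 differs from compound 2 only by a methoxy in place of hydrogen on an aromatic carbon, and in this assay this gives a 1.1-fold higher number from compound 2 to compound 4 (0.04 log units; within the scatter), so the added group leaves no readable mark on this core. Set beside the earlier pair, the same change behaves alike on both cores: the same change on two cores in this assay, a 1.3-fold lower number (0.10 log units; within the scatter) from compound 1 to compound 3 and a 1.1-fold higher number (0.04 log units; within the scatter) from compound 2 to compound 4, 1.4-fold (0.14 log units) apart, within the scatter of two such steps. This shows that in these two pairs the change can be carried from one core to the other without a step beyond the scatter, but with both steps that small no direction can be read, and two pairs, with the new methoxy in different surroundings, make no rule for the series or for other places on the ring.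

At the place that changes, the compounds shown carry only hydrogen or methoxy, so it remains open whether an ethoxy, a hydroxyl or a chlorine there would also leave the number in place. It also remains open which part of the difference between the core of compound 2 and the core of compound 1 goes with the gap in their numbers, as no pair shown separates those features one at a time.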